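Methoxy placement on the pendant ring and antiproliferative potency

This account rests on a few compounds, and the source may have more. Where it says the series, first, only, none or still open, it means among the compounds named here.

Measured in a functional assay on Jurkat cells (Homo sapiens) for antiproliferative activity, read by MTT assay; on this read-out lower numbers stand for stronger inhibition and higher numbers for weaker inhibition:
compound 1 `COc1ccccc1/C=C1\CCc2cc(OC)c(OC)cc2C1=O` gives > 50000 nM, a limit of the assay.
compound 2 `COc1cccc(/C=C2\CCc3cc(OC)c(OC)cc3C2=O)c1` gives 5000 nM.
compound 3 `COc1ccc(/C=C2\CCc3cc(OC)c(OC)cc3C2=O)c(OC)c1` gives > 50000 nM, a limit of the assay.

Compound 1 and compound 2 differ in 3-methoxyphenyl in place of 2-methoxyphenyl on a double-bonded chain carbon bound to a double-bonded ring carbon; the step is an at least 10-fold lower number from compound 1 to compound 2 (1.00 log units; beyond the scatter). Compound 3 differs from compound 1 by methoxy in place of hydrogen on an aromatic carbon, and the step that the two limits leave unreadable from compound 1 to compound 3. Compound 4 `COc1cc(/C=C2\CCc3cc(OC)c(OC)cc3C2=O)cc(OC)c1` differs from compound 2 by methoxy in place of hydrogen on an aromatic carbon; this is the same kind of change as from compound 1 to compound 3, but the place differs: meta to a large group here, para to a large group there. Going by the values given here, compound 2 holds the only number; the two others sit at the limit of > 50000 nM in this assay, at which 2 of the 3 values shown sit. From compound 2 to compound 4 a step of a 1.6-fold higher number from compound 2 to compound 4 (0.20 log units; within the scatter) is expected, resting on compound 2 at 5000 nM and on the unreadable earlier step. Compound 4 is estimated at 8000 nM, between 2000 nM and 40000 nM.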

Compound 4, half-maximal inhibitory concentration: 5000 nM
The estimate for compound 4 lay 1.6-fold (0.20 log units) above the measured number; low and high end bracket the measured number.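

In this assay, the added methoxy, meta to a large group and meta to a methoxy group, produces no change at the digits printed from compound 2 to compound 4 (within the scatter), so the second methoxy is accommodated on the core of compound 2 with no readable shift. The same kind of change from compound 1 to compound 3 cannot be read, so these data do not show whether the result carries over from one setting to the other: the limit of > 50000 nM in this assay, at which 2 of the 4 values shown sit. The two changes also differ in place, so even a readable pair would not compare one change at one place.

From the compounds shown here alone, whether an amine or a carboxylic acid in place of the added methoxy would shift the number remains open. Also open, going by these compounds, is whether the flat result for this methoxy holds at other places on the pendant ring.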